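A few compounds are considered here, and "the series" means these few. Any claim that something is new, unique, unknown or untested is made for them only; others in the source may bear on it.

Three measured members of the series share the core seen in compound 1 `CC1=C(/C=C/C(=O)/C=C/c2ccccc2[N+](=O)[O-])C(C)(C)CCC1` and differ only in the group on the aromatic carbon: compound 2 `CC1=C(/C=C/C(=O)/C=C/c2ccccc2Br)C(C)(C)CCC1` carries bromo and compound 3 `CC1=C(/C=C/C(=O)/C=C/c2ccccc2F)C(C)(C)CCC1` carries fluoro. In a functional assay on MCF7 cells (Homo sapiens) for cytotoxicity, read by sulforhodamine B assay, with a stated time of 48 h (on this read-out higher numbers stand for weaker inhibition and lower numbers for stronger inhibition), compound 1 gives 10100 nM, compound 2 gives 20700 nM and compound 3 gives 11000 nM. Compound 3 thus sits second highest of the three numbers, with a 1.1-fold higher number from compound 1 to compound 3 (0.04 log units; within the scatter) and a 1.9-fold lower number from compound 2 to compound 3 (0.27 log units; within the scatter), so that neither substitution moved the number beyond the scatter. Compound 4 `CC1=C(/C=C/C(=O)/C=C/c2ccccc2C)C(C)(C)CCC1` carries methyl in place of fluoro on an aromatic carbon. Both bearing steps were small, so for compound 4 a step of a 1.1-fold higher number from compound 3 to compound 4 (0.04 log units; within the scatter) in this assay is expected, that is no shift beyond the scatter. Compound 4 is therefore estimated at 12000 nM in this assay, within 5500 nM to 26000 nM.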

Compound 4, half-maximal inhibitory concentration: 44600 nM
Compound 4: middle estimate off by 3.7-fold (0.57 log units), on the low side, outside the stated range (above it).
By their numbers in this assay, from the lowest: compounds 1, 3 and 2 (each within the scatter of the next, the first and the last beyond it); then compound 4.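

For the compounds shown here, at this position, on an aromatic carbon ortho to a large group, methyl is the first group to separate from the others in this assay, with all three steps beyond the scatter and towards weaker inhibition (a 4.1-fold higher number from compound 3 to compound 4 (0.61 log units; beyond the scatter); a 2.2-fold higher number from compound 2 to compound 4 (0.33 log units; beyond the scatter); a 4.4-fold higher number from compound 1 to compound 4 (0.65 log units; beyond the scatter)). Fluoro, bromo and methyl each count one heavy atom, so that count alone does not set the number here. No measurement at hand explains the methyl result.

From the compounds shown here alone, whether an amine, a methoxy group or a longer chain such as ethyl would follow methyl here remains open.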